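This account rests on a few compounds, and the source may have more. Where it says the series, first, only, none or still open, it means among the compounds named here.

In an ADME assay on MCF7-DOX cells (Homo sapiens) for cytotoxicity, read by MTT assay, with a stated time of 48 h (a lower number here means a stronger inhibitor, a higher number a weaker inhibitor), compound 1 `CCCCCc1c(OC)cc(OC)c(C(=O)/C=C/c2cccc(N3CCNCC3)c2)c1O` gives > 100000 nM, which is a limit of the assay and not a number. Compound 2 `COc1cc(OC)c(C(=O)/C=C/c2cccc(N3CCNCC3)c2)c(O)c1CC=C(C)C` gives 99900 nM, and compound 3 `COc1cc(OC)c(C(=O)/C=C/c2cccc(Cl)c2)c(O)c1CC=C(C)C` gives 59500 nM, so these two numbers stand within the scatter of each other. Compound 4 `COc1cc(OC)c(C(=O)/C=C/c2ccc(Cl)cc2)c(O)c1CC=C(C)C` carries 4-chlorophenyl in place of 3-chlorophenyl on a double-bonded chain carbon bound to a double-bonded chain carbon. Among the compounds with values here, no measured step makes this exchange, so the evidence is indirect. Putting 2-methylprop-1-en-1-yl in place of butyl gives a number no higher from compound 1 to compound 2 (the limit leaves the size open), which sets no size. Putting chloro in place of piperazin-1-yl gives a 1.7-fold lower number from compound 2 to compound 3 (0.23 log units; within the scatter), and this is the only readable size in the series. With the same atoms on both sides of the new change, no shift beyond the scatter is expected in this assay, and the estimated step is a 1.1-fold lower number from compound 3 to compound 4 (0.06 log units; within the scatter). For compound 4 the expected value is 52000 nM, with an estimated range of 23000 nM to 100000 nM.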

Compound 4, half-maximal inhibitory concentration: 43400 nM
Compound 4: middle estimate off by 1.2-fold (0.08 log units), on the high side; low and high end bracket the measured number.
By their numbers in this assay, from the lowest: compounds 4, 3 and 2 (each within the scatter of the next, the first and the last beyond it). At a limit, above all of these: compound 1.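

In this assay, within the data shown here, the exchange of 3-chlorophenyl for 4-chlorophenyl on a double-bonded chain carbon bound to a double-bonded chain carbon gives a 1.4-fold lower number from compound 3 to compound 4 (0.14 log units; within the scatter) and is the first step to keep the same atoms while joining them differently. At this position, moving the chloro group around the ring therefore does not separate the two compounds beyond the scatter. No measurement shown bears on a cause for this step.

On these data alone, it remains open whether 2-chlorophenyl in the same place, or a phenyl carrying methoxy or a carboxylic acid in place of chloro, would give a number beyond the scatter of compound 4. Also open, as far as these compounds go, is whether piperazin-1-yl, set where the chloro group stands in compound 4, would give a number within that scatter.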